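The source may report more compounds than this note shows. Statements on the series, on what has been measured and on what is new or still open speak of the compounds shown alone.

Compound 1 `CNC(=O)c1cc(C(=O)NC2CC2)cn(Cc2cccc(F)c2)c1=O`: >= 133 ug/mL
Compound 2 `CNC(=O)c1cc(C(=O)NC2CC2)c(C)n(Cc2ccccc2)c1=O`: >= 126 ug/mL
Compound 3 `CNC(=O)c1cc(C(=O)NCC(C)C)cn(Cc2ccccc2)c1=O`: 43 ug/mL

In a physicochemical assay for solubility (a higher number here means a more soluble compound, a lower number a less soluble compound), compound 1 stands at >= 133 ug/mL as a limit of the assay, not a number. Compound 2 likewise stands at >= 126 ug/mL as a limit. Compound 3 gives 43 ug/mL as an actual number, the only one among the three. Compound 4 `CNC(=O)c1cc(C(=O)NC2CC2)cn(Cc2cccc(OC)c2)c1=O` differs from compound 1 by methoxy in place of fluoro on an aromatic carbon, meta to a large group, counted as methoxy in place of fluoro on an aromatic carbon in all. Going by the values given here, no measured pair tests this change, so the expected at least 1.1-fold lower number from compound 1 to compound 4 (0.06 log units; that floor lies within the scatter) is small and downward, or none beyond the scatter. In this assay the estimated value for compound 4 is 115 ug/mL with a range from 50 ug/mL to 145 ug/mL as expected here.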

Compound 4, solubility: 79 ug/mL
Estimate against measurement, compound 4: 1.5-fold (0.16 log units) above; low and high end bracket the measured number.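

In this assay, going by these compounds alone, methoxy in place of fluoro on the aromatic carbon gives an at least 1.6-fold lower number from compound 1 to compound 4 (0.22 log units; that floor lies within the scatter) as the first reading of this change at this position. That floor alone does not establish a real drop, and the true step could be larger. The step remains a floor because compound 1 stands at a limit of the assay, not at a number: the limit of >= 133 ug/mL in this assay, at which 1 of the 4 values shown sits.

Going by these compounds, what a hydroxyl or an amine on the same aromatic carbon would give remains open. So does whether methoxy in place of fluoro would give a similar step with an isobutyl group on the amide nitrogen instead of cyclopropyl.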